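The compounds below may be only part of what the source reports. "The series", "measured", "known", "first", "only" and "open" are said of these compounds alone.

Compound 3 `O=C(Cn1c(=O)c(/C=C/c2ccc(O)cc2)nc2ccccc21)NS(=O)(=O)C(F)(F)F` gives 38.9% in a functional assay, tested at 50 uM; a higher number here means a stronger effect of the compound at the concentration tested, a lower number a weaker effect. Among the three measured values it stands second highest: compound 2 `O=C(Cn1c(=O)c(/C=C/c2ccccc2)nc2ccccc21)NS(=O)(=O)C(F)(F)F` gives 35.1%, which lies within the scatter of compound 3, while compound 1 `O=C(Cn1c(=O)c(-c2ccc(O)c(O)c2)nc2ccccc21)NS(=O)(=O)C(F)(F)F` gives 89.6%, far above it. Compound 4 `COc1cc(/C=C/c2nc3ccccc3n(CC(=O)NS(=O)(=O)C(F)(F)F)c2=O)ccc1O` differs from compound 3 in one place: methoxy in place of hydrogen on an aromatic carbon. The closest measured step, a hydroxy entering the same outer ring, was a number 3.8 percentage points higher from compound 2 to compound 3 (within the scatter), within the scatter. The large steps of a number 54.5 percentage points lower from compound 1 to compound 2 (beyond the scatter) and a number 50.7 percentage points lower from compound 1 to compound 3 (beyond the scatter) concern a different change and say little about a methoxy. No step beyond the scatter is therefore expected, so a number 2.1 percentage points higher from compound 3 to compound 4 (within the scatter) is estimated. For compound 4 the expected value is 41%, in the range 25% to 60%.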

Compound 4, a percentage reported as activity, at one concentration (the size of the read-out at that concentration, not a potency): 81.9%
Compound 4: the middle estimate sits 40.9 percentage points below what was measured; the measured number lies above the stated range.
By their numbers in this assay, from the lowest: compounds 2 and 3 (each within the scatter of the next); then compounds 4 and 1 (each within the scatter of the next).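

In this assay methoxy in place of hydrogen, ortho to a hydroxy group, brings a number 43 percentage points higher from compound 3 to compound 4 (beyond the scatter) and so shows that this outer ring responds to substitution, which the added hydroxy alone did not show. Against plain phenyl, 4-hydroxy-3-methoxyphenyl brings a number 46.8 percentage points higher from compound 2 to compound 4 (beyond the scatter) with both groups present. Replacing 3,4-dihydroxyphenyl with 2-(4-hydroxy-3-methoxyphenyl)ethenyl gives a number 7.7 percentage points lower from compound 1 to compound 4 (within the scatter) and so leaves little difference between these two compounds. From the compounds shown here alone, whether an ethoxy, an amine or a chlorine in this place would do the same stays open, as does whether methoxy works without the hydroxy group. Nothing at hand gives a reason for the jump.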